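Working notes: alkyl variation on the double-bonded nitrogen

This account rests on a few compounds, and the source may have more. Where it says the series, first, only, none or still open, it means among the compounds named here.

Measured compounds:
compound 1 `CC(C)C/N=C(\NC#N)Nc1cccnc1`: 20 mg/kg
compound 2 `N#CN/C(=N\C1CCCCC1)Nc1cccnc1`: 20 mg/kg

Both values come from a functional assay on the whole organism (blood, strain Wistar-Okamoto) with Rattus norvegicus as the target, with a stated time of 5 days; on this read-out higher numbers stand for an effect only at larger amounts of compound and lower numbers for an effect already at smaller amounts. Among the compounds with values here, compound 1 stands level with compound 2 at the digits recorded; the only measured step, no change at the digits printed from compound 1 to compound 2 (within the scatter), is no change within the scatter. Compound 3 `CC(C)C(/N=C(\NC#N)Nc1cccnc1)C(C)C` has not been tested. It differs from compound 1 by isopropyl in place of hydrogen on a saturated chain carbon bound to a double-bonded nitrogen and a saturated chain carbon. Within the data shown here, the one step that bears on this, no change at the digits printed from compound 1 to compound 2 (within the scatter), also alters the alkyl group on the double-bonded nitrogen and was flat, so no step beyond the scatter is expected from compound 1 to compound 3 in this assay either. The expected step is no change at the digits printed from compound 1 to compound 3 (within the scatter). Compound 3 is therefore estimated at 20 mg/kg, with a range from 10 mg/kg to 40 mg/kg. This expectation rests on a single flat step between two measured compounds only; no pattern across further alkyl groups can be claimed from it.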

Compound 3, minimum effective dose: 5 mg/kg
The estimate for compound 3 lay 4.0-fold (0.60 log units) above the measured number, and the stated range ends above it.
By their numbers in this assay, from the lowest: compound 3; then compounds 1 and 2 (each within the scatter of the next).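

In this assay, within the data shown here, isopropyl in place of hydrogen on a saturated chain carbon bound to a double-bonded nitrogen and a saturated chain carbon gives a 4.0-fold lower number from compound 1 to compound 3 (0.60 log units; beyond the scatter), the first step beyond the scatter. The earlier change, no change at the digits printed from compound 1 to compound 2 (within the scatter), gave no sign that the alkyl group on the double-bonded nitrogen could move the number, so this position is not indifferent to every change in that group. Nothing available here indicates what lies behind the step.

From the compounds shown here alone, what a smaller group such as methyl or ethyl on the same carbon would give remains open. Also open, going by these compounds, is whether a longer chain or an amine on that carbon would keep the lower number seen with compound 3.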